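This account rests on a few compounds, and the source may have more. Where it says the series, first, only, none or still open, it means among the compounds named here.

Compounds measured in an ADME assay on MRC5 cells (Homo sapiens) for cytotoxicity, read by fluorescence and resazurin assay, with a stated time of 3 days; a higher number here means a weaker inhibitor, a lower number a stronger inhibitor:
compound 1 `Cc1cn(C2CCN(Cc3cccc(Oc4ccccc4)n3)CC2)c(=O)[nH]c1=O`: > 64000 nM
compound 2 `Cc1cn(C2CCN(Cc3cccc(Oc4ccc(O)cc4)n3)CC2)c(=O)[nH]c1=O`: "not determined" (no result reported)
compound 3 `COc1ccc(Oc2cccc(CN3CCC(n4cc(C)c(=O)[nH]c4=O)CC3)c2)cc1`: 28000 nM

Compound 1 `Cc1cn(C2CCN(Cc3cccc(Oc4ccccc4)n3)CC2)c(=O)[nH]c1=O` was tested in this assay, and the result is a limit of the assay rather than a number: compound 1 gives > 64000 nM. Compound 3 `COc1ccc(Oc2cccc(CN3CCC(n4cc(C)c(=O)[nH]c4=O)CC3)c2)cc1` is the only one of the three with a measured number, and in this assay compound 3 gives 28000 nM. Compound 2 `Cc1cn(C2CCN(Cc3cccc(Oc4ccc(O)cc4)n3)CC2)c(=O)[nH]c1=O` has no value in this assay, so it cannot be placed among the others; of the three results shown, one sits at the assay limit of > 64000 nM in this assay, at which 1 of the 3 values shown sits, and one is a number. Compound 4 `Cc1cn(C2CCN(Cc3cccc(Oc4cccc(Cl)c4)n3)CC2)c(=O)[nH]c1=O` has not yet been measured. It differs from compound 2 in one place: 3-chlorophenyl in place of 4-hydroxyphenyl on an oxygen on an aromatic ring. No step between two measured compounds is shown, so the size and direction of any step in this assay from compound 2 to compound 4 cannot be read from the data; the two measured values are close to or at the high end of the assay, so compound 4 is expected to be weak as well. The estimate for compound 4 in this assay is 45000 nM, with a range from 15000 nM to 100000 nM.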

Compound 4, half-maximal inhibitory concentration: > 64000 nM
Compound 4: no number, only a limit; the forecaster's own chance of this, stated with the estimate: 50%; at least 1.4-fold (0.15 log units) between middle value and limit.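

In this assay compound 4 gives > 64000 nM, a limit of the assay and not a number. Among the compounds shown here, compound 1 also stands at a limit, so no step from compound 1 to compound 4 can be read. The compounds shown leave open whether chloro in place of hydrogen on an aromatic carbon changes the result in this assay at all.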